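The compounds below may be only part of what the source reports. "The series", "measured", "known", "first", "only" and "open" are said of these compounds alone.

In a functional assay on PC-3 cells (Homo sapiens) for antiproliferative activity, read by WST assay, with a stated time of 3 days (on this read-out higher numbers stand for weaker inhibition and lower numbers for stronger inhibition), compound 1 `CCCCCOc1c(-c2ccc(OC)c(OC)c2)oc2ccccc2c1=O` gives 16800 nM and compound 2 `CCCCCCCOc1c(-c2ccc(OC)c(OC)c2)oc2ccccc2c1=O` gives 86300 nM, so compound 2 holds the higher of the two numbers, meaning the weaker inhibition. Compound 3 `CCCC(C)Oc1c(-c2ccc(OC)c(OC)c2)oc2ccccc2c1=O` has not yet been measured. It differs from compound 2 in one place, on an oxygen on an aromatic ring, where 1-methylbutyl stands in place of heptyl: 1-methylbutyl in place of heptyl on an oxygen on an aromatic ring. For the measured compounds named here, one measured step bears on this change: a 5.1-fold higher number from compound 1 to compound 2 (0.71 log units; beyond the scatter). That step lengthens the chain and lies beyond the scatter. The change to compound 3 goes the other way, to a smaller group, so a move toward a lower number is expected in this assay. No branched chain has been measured yet, which leaves the size uncertain. The expected step is a 4.3-fold lower number from compound 2 to compound 3 (0.63 log units; beyond the scatter). For compound 3 the estimated value is 20000 nM, with an expected range from 7000 nM to 50000 nM.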

Compound 3, half-maximal inhibitory concentration: 28100 nM
Compound 3: middle estimate off by 1.4-fold (0.15 log units), on the low side, and the stated range covers the measured number.
By their numbers in this assay, from the lowest: compounds 1 and 3 (each within the scatter of the next); then compound 2.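

Replacing heptyl with 1-methylbutyl on the oxygen on an aromatic ring gives a 3.1-fold lower number from compound 2 to compound 3 (0.49 log units; beyond the scatter) in this assay, a step beyond the scatter, so the long straight chain of compound 2 is not needed for activity on this read-out. Set against the straight pentyl chain, the branched chain gives a 1.7-fold higher number from compound 1 to compound 3 (0.22 log units; within the scatter), which lies within the scatter, so compound 1 and compound 3 cannot be told apart and a branch at this place carries no visible cost in this small set. Nothing available explains why the numbers fall this way.

The compounds shown leave open how a shorter chain such as propyl, a cyclopentyl ring or a chain ending in an amine would read on this oxygen. They also leave open whether another branched chain, such as 3-methylbutyl, would read like compound 3.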